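This account rests on a few compounds, and the source may have more. Where it says the series, first, only, none or still open, it means among the compounds named here.

Of the compounds shown here, three built on one shared core have been tested in a functional assay on KB cells (Homo sapiens) for cytotoxicity, read by resazurin assay, with a stated time of 3 days; a lower number here means a stronger inhibitor, a higher number a weaker inhibitor. Compound 1 `CC(C)(CNC(=O)c1ccc2ccccc2c1)CC1=C(O)C(=O)c2ccccc2C1=O` gives 9000 nM. Compound 2 `COC1=C(CC(C)(C)CNC(=O)c2ccccc2)C(=O)c2ccccc2C1=O` gives 117000 nM. Compound 3 `COC1=C(CC(C)(C)CNC(=O)c2ccc3ccccc3c2)C(=O)c2ccccc2C1=O` gives 34100 nM, which places it second highest of the three numbers, with compound 2 as its nearest neighbour and compound 1 as its furthest. Two measured steps lead to compound 3. a 3.8-fold higher number from compound 1 to compound 3 (0.58 log units; beyond the scatter). a 3.4-fold lower number from compound 2 to compound 3 (0.54 log units; beyond the scatter).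

Compound 4 `COC1=C(CC(C)(C)CNC(=O)c2ccc3ccccc3c2OC)C(=O)c2ccccc2C1=O` has not yet been measured. It differs from compound 3 in one place: methoxy in place of hydrogen on an aromatic carbon. Among the measured compounds shown here, neither measured step is of this kind: one adds a methyl to an oxygen on the core, the other replaces phenyl by naphthalen-2-yl on the carbonyl carbon, and no measured pair adds a methoxy to that fused ring system. For the measured compounds named here, there is thus no measured precedent for this change, and the expected step in this assay is small, in no firm direction, and most plausibly within the scatter. The step expected from compound 3 to compound 4 is a 1.1-fold lower number from compound 3 to compound 4 (0.06 log units; within the scatter). Compound 4 is therefore expected to give about 30000 nM, within a range from 10000 nM to 90000 nM.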

Compound 4, half-maximal inhibitory concentration: 64100 nM
Compound 4: the middle estimate sits 2.1-fold (0.33 log units) below what was measured; the range from low to high includes it.
By their numbers in this assay, from the lowest: compound 1; then compounds 3, 4 and 2 (each within the scatter of the next, the first and the last beyond it).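

In this assay, placing a methoxy on the aromatic carbon ortho to a fused ring and ortho to a large group gives a 1.9-fold higher number from compound 3 to compound 4 (0.27 log units; within the scatter), so compound 3 and compound 4 cannot be told apart by this read-out. This is the only change shown that adds a group to the naphthalen-2-yl ring itself, and it indicates that this crowded aromatic carbon can carry a methoxy without a difference beyond the scatter, whereas the two earlier steps, one on the core oxygen and one swapping phenyl for naphthalen-2-yl, both went beyond it. Nothing measured here accounts for this result.

The compounds shown leave open whether a smaller hydroxy, or an amine or a carboxylic acid, on this same aromatic carbon would also stay within the scatter, and whether a methoxy on the other aromatic carbons of the ring would do so. They also leave open whether the same methoxy would behave alike on the core of compound 1, which has a hydroxy where compound 4 has a methoxy on the core.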